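This account rests on a few compounds, and the source may have more. Where it says the series, first, only, none or still open, it means among the compounds named here.

In a functional assay on MCF7 cells (Homo sapiens) for inhibition, read by MTT assay, with a stated time of 72 h (a lower number here means a stronger inhibitor, a higher number a weaker inhibitor), two compounds have been measured so far. Compound 1 (`COc1cc(NC(C)CCCNC(=O)NNC(=O)Nc2cccc(F)c2)c2ncccc2c1`) gives 150 nM, and compound 2 (`COc1cc(NC(C)CCCNC(=O)NNC(=O)Nc2ccc(O)cc2)c2ncccc2c1`) gives 2600 nM, the higher of the two numbers and so the weaker inhibitor. Compound 3 (`COc1cc(NC(C)CCCNC(=O)Nc2ccc(O)cc2)c2ncccc2c1`) differs from compound 2 on an amide-type nitrogen: 4-hydroxyphenyl in place of ((4-hydroxyphenyl)carbamoyl)amino on an amide-type nitrogen. Within the data shown here, no measured step covers this exact change. The only one available, a 17-fold higher number from compound 1 to compound 2 (1.24 log units; beyond the scatter), is large, but it comes from placing 4-hydroxyphenyl where 3-fluorophenyl stood. Among the measured compounds shown here, it shows only that one change on an amide-type nitrogen can move the number far, and it gives no direction here. The central expectation is therefore no shift beyond the scatter, though with wide uncertainty either way. The expected step is a 1.2-fold higher number from compound 2 to compound 3 (0.06 log units; within the scatter). For compound 3 the estimated value is 3000 nM, with an expected range from 500 nM to 18000 nM.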

Compound 3, half-maximal inhibitory concentration: 5200 nM
Compound 3: the middle estimate sits 1.7-fold (0.24 log units) below what was measured; the measured number falls inside the stated range.
By their numbers in this assay, from the lowest: compound 1; then compounds 2 and 3 (each within the scatter of the next).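

In this assay, the step is a 2.0-fold higher number from compound 2 to compound 3 (0.30 log units; within the scatter), so with 4-hydroxyphenyl at the end of the group on the amide-type nitrogen, the ((4-hydroxyphenyl)carbamoyl)amino unit can give way to 4-hydroxyphenyl alone without a shift beyond the scatter. Replacing ((3-fluorophenyl)carbamoyl)amino in the same place gives a large step, a 35-fold higher number from compound 1 to compound 3 (1.54 log units; beyond the scatter), so compound 1 stays clearly apart from both compounds that carry 4-hydroxyphenyl. Nothing available gives a measured reason for these numbers.

The compounds shown leave open whether 3-fluorophenyl placed directly on the amide-type nitrogen would stay close to compound 1 or fall with compound 3. They also do not show how an amine or a carboxylic acid on the phenyl ring would behave at this position.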